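This account rests on a few compounds, and the source may have more. Where it says the series, first, only, none or still open, it means among the compounds named here.

Compound 1 `CC1(C)C(=O)N(c2ccc(SC(F)(F)F)cc2)C(=O)N1Cc1ccnc(N2CCCCC2)c1` belongs to a set of three compounds that share one core and differ only in the group on the aromatic carbon of the pyridine-type ring. In a physicochemical assay for solubility, read by nephelometry (a lower number here means a less soluble compound, a higher number a more soluble compound), compound 1 gives only a limit, < 0.024 ug/mL, and no number. Compound 2 `CN(C)c1cc(CN2C(=O)N(c3ccc(SC(F)(F)F)cc3)C(=O)C2(C)C)ccn1` likewise gives only a limit, < 0.022 ug/mL, in this assay. Compound 3 `CC1(C)C(=O)N(c2ccc(SC(F)(F)F)cc2)C(=O)N1Cc1ccnc(NCc2ccccc2)c1` in turn gives only a limit, < 0.026 ug/mL. The steps among them are therefore a step that the two limits leave unreadable from compound 1 to compound 2, a step that the two limits leave unreadable from compound 1 to compound 3 and a step that the two limits leave unreadable from compound 2 to compound 3; all that is known is that the three values sit at the limit of < 0.022 ug/mL in this assay, at which 1 of the 3 values shown sits, the limit of < 0.024 ug/mL in this assay, at which 1 of the 3 values shown sits, and (the limit of < 0.026 ug/mL in this assay, at which 1 of the 3 values shown sits).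

Compound 4 `CCc1cc(CN2C(=O)N(c3ccc(SC(F)(F)F)cc3)C(=O)C2(C)C)ccn1` is not yet measured. It differs from compound 1 by ethyl in place of piperidin-1-yl on an aromatic carbon. Going by the values given here, none of the measured steps gives a readable size, so no direction beyond the scatter can be inferred for this step. The estimate for compound 4 in this assay is 0.03 ug/mL, spanning 0.01 ug/mL to 0.3 ug/mL, which would mean an expected step of an at least 1.2-fold higher number from compound 1 to compound 4 (0.09 log units; that floor lies within the scatter); a further limit is the most likely outcome.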

Compound 4, solubility: < 0.022 ug/mL
Compound 4 gave a limit, no number; the forecaster's own chance of this, stated with the estimate: 70%; middle value at least 1.3-fold (0.13 log units) away from the limit.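

Compound 4 also gives only a limit in this assay, so its steps from compound 1, compound 2 and compound 3 cannot be read. The compounds shown leave open what any of the four actual solubility values is, and whether the group on the aromatic carbon shifts them.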